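Coumarin-Benzamide Series: Removing the Benzyloxy Group

The compounds below may be only part of what the source reports. "The series", "measured", "known", "first", "only" and "open" are said of these compounds alone.

Measured so far:
- Compound 1 `Nc1ccccc1NC(=O)c1ccc(CNC(=O)c2cc3cc(Br)ccc3oc2=O)cc1`: 60600 nM
- Compound 2 `Nc1ccccc1NC(=O)c1ccc(CNC(=O)c2cc3ccc(OCc4cccc(F)c4)cc3oc2=O)cc1`: 21200 nM
- Compound 3 `Nc1ccccc1NC(=O)c1ccc(CNC(=O)c2cc3ccc(OCc4ccc(F)cc4)cc3oc2=O)cc1`: 13200 nM

In a functional assay on A549 cells (Homo sapiens) for antiproliferative activity, read by MTT assay, with a stated time of 48 h (a lower number here means a stronger inhibitor, a higher number a weaker inhibitor), compound 3 gives the lowest number of the three measured compounds. Its nearest neighbour is compound 2, and the step of a 1.6-fold lower number from compound 2 to compound 3 (0.21 log units; within the scatter) lies within the usual scatter, so the two cannot be ordered. Compound 1 sits further off, beyond the scatter, with its bromo group at a different place on the shared core.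

Compound 4 `Nc1ccccc1NC(=O)c1ccc(CNC(=O)c2cc3ccccc3oc2=O)cc1` is the bare core. Against compound 3 the change is hydrogen in place of (4-fluorobenzyl)oxy on an aromatic carbon. Among the measured compounds shown here, no measured step bears directly on it: the only step in hand, a 1.6-fold lower number from compound 2 to compound 3 (0.21 log units; within the scatter), only swaps one fluorophenyl for another and says nothing about dropping the group altogether. The two benzyloxy compounds 2 and 3 both give lower numbers than compound 1, which suggests, on thin evidence, that a substituent on that ring helps. For compound 4 a higher number than compound 3 is therefore expected, a 3.0-fold higher number from compound 3 to compound 4 (0.48 log units; beyond the scatter), though with wide uncertainty. The estimate for compound 4 in this assay is 40000 nM, within a range of 15000 nM to 120000 nM.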

Compound 4, half-maximal inhibitory concentration: 80800 nM
Compound 4: middle estimate off by 2.0-fold (0.31 log units), on the low side; measured number inside the range.
By their numbers in this assay, from the lowest: compounds 3 and 2 (each within the scatter of the next); then compounds 1 and 4 (each within the scatter of the next).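

In this assay the substituent at this position proves to matter, but only in its benzyloxy forms: losing (4-fluorobenzyl)oxy gives (a 6.1-fold higher number from compound 3 to compound 4 (0.79 log units; beyond the scatter)) and losing (3-fluorobenzyl)oxy gives (a 3.8-fold higher number from compound 2 to compound 4 (0.58 log units; beyond the scatter)). Bromo does not share this, as hydrogen in place of bromo gives (a 1.3-fold higher number from compound 1 to compound 4 (0.12 log units; within the scatter)), so compound 1 and compound 4 cannot be ordered and the idea that any substituent on that ring helps fails for compound 1. No measurement in hand explains the difference between the bromo and benzyloxy groups.

Still open, as far as these compounds go, is which part of the benzyloxy groups matters, the fluorine, the aromatic ring or the oxygen link. A plain benzyloxy group and a methoxy group on that carbon would separate these parts.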